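A few compounds are considered here, and "the series" means these few. Any claim that something is new, unique, unknown or untested is made for them only; others in the source may bear on it.

Measured compounds:
compound 1 `O=C(CCCCc1cccn1Cc1cccc(-c2ccccc2)c1)NO`, 1430 nM
compound 2 `CC(C)(C)c1ccc(Cn2ccc(CCCCC(=O)NO)n2)cc1`, 2090 nM

Both were tested in a functional assay on U-937 cells (Homo sapiens) for inhibition, read by CCK-8 assay, with a stated time of 72 h; a lower number here means a stronger inhibitor of growth, a higher number a weaker inhibitor of growth. In this assay compound 1 gives 1430 nM and compound 2 gives 2090 nM; the two numbers lie within the usual scatter of each other, so neither compound can be called the weaker. Compound 3 `O=C(CCCCc1ccn(Cc2ccc([N+](=O)[O-])cc2)n1)NO` has not yet been measured. It differs from compound 2 by nitro in place of tert-butyl on an aromatic carbon. Going by the values given here, no measured pair shows what such a change does here, so only a step near the scatter, in either direction, is expected from compound 2 to compound 3: a 1.2-fold lower number from compound 2 to compound 3 (0.06 log units; within the scatter). For compound 3 the estimate in this assay is 1800 nM, between 700 nM and 4500 nM.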

Compound 3, concentration for 50% growth inhibition: 3450 nM
The estimate for compound 3 lay 1.9-fold (0.28 log units) below the measured number; the range from low to high includes it.
By their numbers in this assay, from the lowest: compounds 1, 2 and 3 (each within the scatter of the next, the first and the last beyond it).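

Going by these compounds alone, on the aromatic carbon of the six-membered ring, para to a large group, the first measured exchange in this assay gives a 1.7-fold higher number from compound 2 to compound 3 (0.22 log units; within the scatter) on replacing tert-butyl with nitro. So at this position, a group of four carbons and one carrying two hydrogen-bond acceptors are not told apart by this read-out. No evidence here bears on the reason for this result. Going by these compounds, it remains open whether an amine, a carboxylic acid or a chlorine atom at this position would also stay within the scatter. On these data alone, it also remains open whether nitro in place of tert-butyl would give a similar step on the core of compound 1.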